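Isopropyl for Methoxy: Inhibition in a Rat Model

This account rests on a few compounds, and the source may have more. Where it says the series, first, only, none or still open, it means among the compounds named here.

Compound 1 `COc1cccc(-c2cc(Cl)cc(C(=O)Nc3nn[nH]n3)n2)c1`: 95%
Compound 2 `COc1ccc(-c2cc(Cl)cc(C(=O)Nc3nn[nH]n3)n2)cc1`: 100%

In a functional assay on the whole organism with Rattus norvegicus as the target, at a dose of 3 mg/kg by the oral route (a lower number here means a weaker effect, a higher number a stronger effect of the compound at the dose given), compound 2 gives 100%, the higher of the two numbers, with compound 1 a few points lower, within the scatter. Compound 3 `CC(C)c1ccc(-c2cc(Cl)cc(C(=O)Nc3nn[nH]n3)n2)cc1` differs from compound 2 by one change: isopropyl in place of methoxy on an aromatic carbon. Among the measured compounds shown here, no step between measured compounds is available, so the size of this change cannot be read from the data. Because compound 2 gives 100%, near the top of the scale, little room remains to rise; a small drop within the scatter is expected. The estimated step from compound 2 to compound 3 is a number 10 percentage points lower from compound 2 to compound 3 (within the scatter). Compound 3 is estimated at 90%, with a range from 65% to 100%.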

Compound 3, a percentage reported as inhibition, in the whole organism at one dose (the size of the read-out at that dose, not a potency): 68%
The estimate for compound 3 lay 22 percentage points above the measured number; the measured number falls inside the stated range.
By their numbers in this assay, from the lowest: compound 3; then compounds 1 and 2 (each within the scatter of the next).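

In this assay the read-out comes out a number 32 percentage points lower from compound 2 to compound 3 (beyond the scatter) when isopropyl replaces methoxy at this place, para to a large group. The two earlier compounds both carry methoxy, so they could not show that the effect at this dose depends so strongly on the group held here. Nothing at hand explains the loss.

Going by these compounds, whether an amine, a carboxylic acid or a simple ethyl group at this place would hold the effect stays open. A single dose also leaves the potency of these compounds unknown.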